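Swapping one pyridine for another on the thiazole acid core

A few compounds are considered here, and "the series" means these few. Any claim that something is new, unique, unknown or untested is made for them only; others in the source may bear on it.

In an in vitro functional assay on HEK285-7 cells for antagonist activity at prostaglandin D2 receptor 2 (Homo sapiens), read by BRET and beta-arrestin recruitment (on this read-out lower numbers stand for stronger inhibition and higher numbers for weaker inhibition), compound 1 `O=C(O)Cc1sc(C(c2ccc(F)cc2)c2ccc(F)cc2)nc1-c1ccoc1` gives 130 nM. Compound 2 `CN(C)c1cc(-c2nc(C(c3ccc(F)cc3)c3ccc(F)cc3)sc2CC(=O)O)ccn1` gives > 100000 nM in this assay, which is a limit and not a number, sitting at the limit of > 100000 nM in this assay, at which 1 of the 2 values shown sits. On these data alone, the step of an at least 760-fold higher number from compound 1 to compound 2 (2.88 log units; beyond the scatter) therefore shows a loss of activity whose true size is unknown. Compound 3 `Cc1cc(-c2nc(C(c3ccc(F)cc3)c3ccc(F)cc3)sc2CC(=O)O)cnc1N` differs from compound 2 in one place: 6-amino-5-methylpyridin-3-yl in place of 2-(dimethylamino)pyridin-4-yl on an aromatic carbon. Among the compounds with values here, no measured step compares two pyridines with different substituents, so the only guide is that the pyridine of compound 2 lost what the furan of compound 1 had, which makes a full recovery unlikely but leaves the size of the step open. Compound 3 is expected to sit between the two measured values, with the estimated change an at least 5.0-fold lower number from compound 2 to compound 3 (0.69 log units; beyond the scatter). The estimate for compound 3 in this assay is 20000 nM, with a range from 1000 nM to 100000 nM.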

Compound 3, half-maximal inhibitory concentration: > 100000 nM
Compound 3: a limit, no number (the forecaster's own chance of this, stated with the estimate: 45%); middle value at least 5.0-fold (0.69 log units) from the limit.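

Placing 6-amino-5-methylpyridin-3-yl on this aromatic carbon in place of furan-3-yl gives an at least 760-fold higher number from compound 1 to compound 3 (2.88 log units; beyond the scatter) in this assay, a large step towards weaker inhibition. The loss seen with compound 2 is therefore not confined to its 2-(dimethylamino)pyridin-4-yl group, since a differently substituted pyridine at the same position also falls far short of compound 1. Neither pyridine can be ranked against the other, and the step between them cannot be read: the limit of > 100000 nM in this assay, at which 2 of the 3 values shown sit.

These compounds do not separate the effect of the pyridine ring from that of its substituents, since both pyridines carry an amino nitrogen group. An unsubstituted pyridin-3-yl, or a pyridine bearing only a methyl group, would test that, and a thiophen-3-yl would show how closely the ring must resemble furan-3-yl.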